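A few compounds are considered here, and "the series" means these few. Any claim that something is new, unique, unknown or untested is made for them only; others in the source may bear on it.

Compound 1 `CCOC(=O)C1=C(C)NC(=O)NC1c1cn(C(=O)CNc2ccccc2[N+](=O)[O-])c2ccccc12`: 40 ug/mL
Compound 2 `CCOC(=O)C1=C(C)NC(=O)NC1c1cn(C(=O)CNc2ccc([N+](=O)[O-])cc2)c2ccccc12`: > 1000 ug/mL

Both compounds were tested in a functional assay on MCF7 cells (Homo sapiens) for cytotoxicity, read by MTT assay, with a stated time of 72 h; on this read-out higher numbers stand for weaker inhibition and lower numbers for stronger inhibition. Compound 2 stands at > 1000 ug/mL, which is a limit of the assay and not a number. The next compound, compound 3 `CCOC(=O)C1=C(C)NC(=O)NC1c1cn(C(=O)CNc2ccc(Cl)cc2)c2ccccc12`, has chloro in place of nitro on an aromatic carbon, para to a large group: chloro in place of nitro on an aromatic carbon.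

Going by the values given here, only one measured step bears on this change. Putting 4-nitrophenyl in place of 2-nitrophenyl on an amine nitrogen gave an at least 25-fold higher number from compound 1 to compound 2 (1.39 log units; beyond the scatter), which is large. That step moved the same nitro group rather than replacing it, so it is only a loose guide. Still, it shows that this phenyl ring can carry large changes in this assay, so a sizeable move to a lower number, meaning stronger inhibition, is expected. The estimated change is an at least 5.0-fold lower number from compound 2 to compound 3 (0.69 log units; beyond the scatter). For compound 3 the expected value is 200 ug/mL, with an estimated range of 30 ug/mL to 1000 ug/mL.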

Compound 3, half-maximal inhibitory concentration in the MCF7 assay: 200 ug/mL
Beside the measured number, compound 3's estimate shows no gap at the digits printed; measured number inside the range.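

In the MCF7 assay, putting chloro in place of nitro at this spot on the ring gives an at least 5.0-fold lower number from compound 2 to compound 3 (0.69 log units; beyond the scatter), so the group itself matters here, not only where the nitro sits. On these data alone, compound 2 stands at > 1000 ug/mL, which is a limit of the assay and not a number, so the true size of this step is unknown. The 4-chlorophenyl group still does not match the 2-nitrophenyl group on the amine nitrogen: a 5.0-fold higher number from compound 1 to compound 3 (0.70 log units; beyond the scatter).

In a physicochemical assay for lipophilicity (on this read-out lower numbers stand for lower lipophilicity and higher numbers for higher lipophilicity), compound 2 gives 1.48 and compound 3 gives 2.04. As far as these compounds go, two compounds cannot tell whether the rise in lipophilicity is what goes with the stronger inhibition: the measured partition coefficient of compound 2, 1.48, and of compound 3, 2.04, a number 0.56 log units higher (beyond the scatter) Also open is how a methoxy group or a carboxylic acid would read at this spot, and whether a chloro placed where compound 1 carries its nitro would match compound 1.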